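Shifting the Chlorine on the Urea Aryl Ring

A few compounds are considered here, and "the series" means these few. Any claim that something is new, unique, unknown or untested is made for them only; others in the source may bear on it.

Measured compounds:
compound 1, `O=C(Nc1cccc(C(=O)O)c1)N[C@H]1CC[C@H](Oc2ccc(F)cc2)CC1`: > 20000 nM
compound 2, `O=C(Nc1cccc([N+](=O)[O-])c1)N[C@H]1CC[C@H](Oc2ccc(F)cc2)CC1`: 6700 nM
compound 3, `O=C(Nc1ccc(Cl)cc1)N[C@H]1CC[C@H](Oc2ccc(F)cc2)CC1`: > 20000 nM

In a functional assay on CRL2813 cells (Homo sapiens) for cytotoxicity, read by sulforhodamine B assay, with a stated time of 5 days (on this read-out lower numbers stand for stronger inhibition and higher numbers for weaker inhibition), compound 1 gives > 20000 nM, which is a limit of the assay rather than a number. Compound 2 gives 6700 nM. Compound 3 gives > 20000 nM, again only a limit. the limit of > 20000 nM in this assay, at which 2 of the 3 values shown sit, marks where two of the three values sit, so compound 3 stands at the weak end of what was measured. The measured steps are an at least 2.9-fold lower number from compound 1 to compound 2 (0.47 log units; beyond the scatter), an at least 2.9-fold higher number from compound 2 to compound 3 (0.47 log units; beyond the scatter) and a step that the two limits leave unreadable from compound 1 to compound 3.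

Compound 4, `O=C(Nc1ccccc1Cl)N[C@H]1CC[C@H](Oc2ccc(F)cc2)CC1`, differs from compound 3 by 2-chlorophenyl in place of 4-chlorophenyl on an amide-type nitrogen. Going by the values given here, none of the measured steps exchanges one chlorophenyl for another; each swaps in a different substituent, so none bears directly on this change. Compound 4 is therefore expected to stay close to compound 3, with a number no higher from compound 3 to compound 4 (the limit leaves the size open) expected to remain within the scatter. Compound 4 is estimated at 20000 nM, within 7000 nM to 60000 nM.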

Compound 4, half-maximal inhibitory concentration: 9100 nM
Estimate against measurement, compound 4: 2.2-fold (0.34 log units) above; measured number inside the range.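

Moving the chlorine, with the same atoms on the ring, gives an at least 2.1-fold lower number from compound 3 to compound 4 (0.34 log units; beyond the scatter) in this assay and so moves the reading beyond the scatter. Going by these compounds alone, this shows that where the chlorine sits on the phenyl ring matters, something no earlier step could show, as each of them exchanged one substituent for a different one. The 2-chlorophenyl group also gives an at least 2.1-fold lower number from compound 1 to compound 4 (0.34 log units; beyond the scatter) against the 3-carboxyphenyl group, whereas a 1.4-fold higher number from compound 2 to compound 4 (0.13 log units; within the scatter) leaves it level with the 3-nitrophenyl group, within the scatter.

Going by these compounds, whether a bromine or a methyl group in place of this chlorine would read the same remains open. On these data alone, the full size of the step from the 4-chlorophenyl group also stays open, since the value of compound 3 is only a limit: the limit of > 20000 nM in this assay, at which 2 of the 4 values shown sit.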